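The source may hold more compounds than are shown below. What is called first, only, known or untested is meant among the compounds shown, and "the series" means these compounds.

The series shares one core, seen in compound 1 `COc1ccc2[nH]c(C(=O)N3CC(=O)N(Cc4ccccc4)[C@@H](CN4CCN(S(=O)(=O)c5ccccc5)CC4)C3)cc2c1`, compound 2 `COc1ccc2[nH]c(C(=O)N3CC(=O)N(Cc4ccccc4)[C@@H](N4CCc5ccccc54)C3)cc2c1` and compound 3 `COc1ccc2[nH]c(C(=O)N3CC(=O)N(Cc4ccccc4)[C@@H](CN4CCN(Cc5ccccn5)CC4)C3)cc2c1`, and is followed in a physicochemical assay for solubility, read by spectrophotometry, in phosphate buffer, with a stated time of 2 h, at pH 7.4; a lower number here means a less soluble compound, a higher number a more soluble compound. In this assay compound 1 gives 16900 nM and compound 2 gives 7000 nM, the lowest of the two numbers, with compound 1 standing a bit higher. Compound 3 reaches > 100000 nM, which is a limit of this assay and not a number (the limit of > 100000 nM in this assay, at which 1 of the 3 values shown sits). Within the data shown here, the one measured step, an at least 5.9-fold higher number from compound 1 to compound 3 (0.77 log units; beyond the scatter), changes a group on a ring nitrogen. Compound 4 `COc1ccc2[nH]c(C(=O)N3CC(=O)N(Cc4ccccc4)[C@@H](CN4CCC5(CCCC5)CC4)C3)cc2c1` is not yet measured; it differs from compound 2 in another place: a group of 11 heavy atoms (10 carbon, 1 nitrogen; one five-membered non-aromatic ring of carbon only, one six-membered non-aromatic ring with 1 hetero atom) in place of a group of 9 heavy atoms (8 carbon, 1 nitrogen; one five-membered non-aromatic ring with 1 hetero atom, one six-membered aromatic ring of carbon only), on a saturated ring carbon. Among the measured compounds shown here, no measured step covers an exchange of this kind, so the step from compound 1 to compound 3 gives no direct guide, and the account expects compound 4 to stay near compound 2, with the step of a 1.1-fold higher number from compound 2 to compound 4 (0.06 log units; within the scatter) expected to lie within the usual scatter. In this assay compound 4 is therefore estimated at 8000 nM, between 2500 nM and 30000 nM.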

Compound 4, solubility: 5000 nM
Compound 4: the middle estimate sits 1.6-fold (0.20 log units) above what was measured, and the stated range covers the measured number.
By their numbers in this assay, from the lowest: compounds 4 and 2 (each within the scatter of the next); then compound 1. At a limit, above all of these: compound 3.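

In this assay, putting the group of 11 heavy atoms in place of 2,3-dihydro-1H-indol-1-yl, on a saturated ring carbon next to the ring nitrogen, gives a 1.4-fold lower number from compound 2 to compound 4 (0.15 log units; within the scatter). Among these compounds, this is the first measured step at this place, whereas the earlier step changed a group on an amine nitrogen in a ring, and it shows that an exchange removing the six-membered aromatic ring of carbon only, with hydrogen-bond donors, acceptors and net charge counted the same on both groups, stays within the scatter. The compounds shown offer no measurement that accounts for this step.

They leave open whether a carboxylic acid or an amine carried on the group at this place would give a step beyond the scatter. From the compounds shown here alone, a morpholine at this place also remains open.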